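Replacing 2,6-dimethoxyphenyl with 1-benzothiophen-2-yl

A few compounds are considered here, and "the series" means these few. Any claim that something is new, unique, unknown or untested is made for them only; others in the source may bear on it.

compound 1 `O=C1c2ccccc2C(=O)N1CCOC(=S)N(C(=O)c1ccccc1[N+](=O)[O-])c1ccc(Cl)cc1`: 21000 nM
compound 2 `O=C1c2ccccc2C(=O)N1CCOC(=S)N(C(=O)c1ccc(Cl)cc1Cl)c1ccc(Cl)cc1`: 18000 nM
compound 3 `COc1cccc(OC)c1C(=O)N(C(=S)OCCN1C(=O)c2ccccc2C1=O)c1ccc(Cl)cc1`: 69000 nM

In an ADME assay on MT4 cells (Homo sapiens) for cytotoxicity, read by MTT assay (on this read-out lower numbers stand for higher toxicity in this test and higher numbers for lower toxicity in this test), compound 3 stands highest of the three (69000 nM), beyond the scatter from both others. Compound 4 `O=C1c2ccccc2C(=O)N1CCOC(=S)N(C(=O)c1cc2ccccc2s1)c1ccc(Cl)cc1` carries 1-benzothiophen-2-yl in place of 2,6-dimethoxyphenyl on a carbonyl carbon. Three measured steps change this same place. One is a 1.2-fold lower number from compound 1 to compound 2 (0.07 log units; within the scatter) and the two modest ones are a 3.3-fold higher number from compound 1 to compound 3 (0.52 log units; beyond the scatter) and a 3.8-fold higher number from compound 2 to compound 3 (0.58 log units; beyond the scatter) in size. Among the measured compounds shown here, no measured compound carries 1-benzothiophen-2-yl, so the expectation is only a modest fall toward the other two values. The expected step is a 2.6-fold lower number from compound 3 to compound 4 (0.41 log units; beyond the scatter) in this read-out. For compound 4 the estimated value is 27000 nM with an expected range of 10000 nM to 70000 nM overall.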

Compound 4, half-maximal cytotoxic concentration: 56000 nM
Beside the measured number, compound 4's estimate is 2.1-fold (0.32 log units) below it, and the stated range covers the measured number.
By their numbers in this assay, from the lowest: compounds 2 and 1 (each within the scatter of the next); then compounds 4 and 3 (each within the scatter of the next).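

In this assay the change gives a 1.2-fold lower number from compound 3 to compound 4 (0.09 log units; within the scatter) at this carbonyl carbon, so 1-benzothiophen-2-yl stays level with 2,6-dimethoxyphenyl and the high end of the read-out is not unique to that one group. Both a 3.1-fold higher number from compound 2 to compound 4 (0.49 log units; beyond the scatter) and a 2.7-fold higher number from compound 1 to compound 4 (0.43 log units; beyond the scatter) lie beyond the scatter, which sets the new group with compound 3 and apart from 2,4-dichlorophenyl and 2-nitrophenyl. Nothing available explains this split. Where an unsubstituted phenyl or a cyclohexyl group on this carbonyl carbon would fall remains open.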